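Alkyl Chain Replaced by Benzyl: Expected Potency

The compounds below may be only part of what the source reports. "The series", "measured", "known", "first", "only" and "open" are said of these compounds alone.

Measured so far:
compound 1 `CCCCSc1nnc(COc2cc(C)c3c(C)cc(=O)oc3c2)o1` in a functional assay on MCF7 cells (Homo sapiens) for antiproliferative activity, read by MTT assay, with a stated time of 24 h (a higher number here means a weaker inhibitor, a lower number a stronger inhibitor), gives a limit only, > 100000 nM
compound 2 `CCCCCCSc1nnc(COc2cc(C)c3c(C)cc(=O)oc3c2)o1` in this assay gives a limit only, > 100000 nM

Both values are limits of the assay, not numbers, so the step that the two limits leave unreadable from compound 1 to compound 2 cannot be read; (the limit of > 100000 nM in this assay, at which 2 of the 2 values shown sit). Compound 2 therefore stands at the limit, with no measured potency. Compound 3 `Cc1cc(OCc2nnc(SCc3ccccc3)o2)cc2oc(=O)cc(C)c12` differs from it by phenyl in place of pentyl on a saturated chain carbon bound to a sulfur. No readable measured step bears on this change. Compound 3 is thus expected to stay at or near the limit, with an expected step of a number no higher from compound 2 to compound 3 (the limit leaves the size open) and an estimate of 100000 nM (range 30000 nM to 300000 nM).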

Compound 3, half-maximal inhibitory concentration: > 100000 nM
Compound 3 was reported as a limit (the forecaster's own chance of this, stated with the estimate: 75%); the middle value lies on the limit itself.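

No step can be read among compound 1, compound 2 and compound 3, since all three sit at the same assay limit: the limit of > 100000 nM in this assay, at which 3 of the 3 values shown sit.

In this assay, from the compounds shown here alone, it stays open whether hexyl and benzyl differ at all, and which change to the shared core would give a measurable potency.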